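The compounds below may be only part of what the source reports. "The series", "measured", "known", "first", "only" and "open" are said of these compounds alone.

Within the data shown here, compound 2 `O=c1c(-c2nnc(-c3ccc(F)cc3)o2)c[nH]c2ncc(-c3cccnc3)cc12` is one of three compounds measured in a functional assay on HCT-116 cells (Homo sapiens) for inhibition, read by MTT assay, with a stated time of 24 h, tested at 5 uM (a lower number here means less inhibition of growth, a higher number more inhibition of growth at the concentration tested), in which compound 2 gives 11.1%. It stands second highest of the three numbers. Its nearest neighbour is compound 3 `O=c1c(-c2nnc(-c3ccc(F)cc3)o2)c[nH]c2ncc(-c3ccncc3)cc12`, which in this assay gives 10.9%, a difference of a number 0.2 percentage points lower from compound 2 to compound 3 (within the scatter). The furthest is compound 1 `N#Cc1ccc(-c2cnc3[nH]cc(-c4nnc(-c5ccc(F)cc5)o4)c(=O)c3c2)cc1`, which in this assay gives 12.6%; the step of a number 1.5 percentage points lower from compound 1 to compound 2 (within the scatter) is likewise within the scatter, as is a number 1.7 percentage points lower from compound 1 to compound 3 (within the scatter). All three measured steps exchange the aryl group on the shared core and none of them moves the number beyond the scatter.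

Compound 4 `O=c1c(-c2nnc(-c3ccc(Cl)cc3)o2)c[nH]c2ncc(-c3cccnc3)cc12` differs from compound 2 by chloro in place of fluoro on an aromatic carbon, that is, 4-fluorophenyl to 4-chlorophenyl. Among the measured compounds shown here, no measured step touches this group, so the measured steps give no direct guide; they only show that the series so far sits in a narrow band. Compound 4 is therefore expected to stay near compound 2, with an estimated step of a number 0.9 percentage points higher from compound 2 to compound 4 (within the scatter). The estimate for compound 4 in this assay is 12%, with a range from 3% to 24%.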

Compound 4, percent growth inhibition at one concentration: 15.9%
Compound 4: middle estimate off by 3.9 percentage points, on the low side; low and high end bracket the measured number.
By their numbers in this assay, from the lowest: compounds 3, 2, 1 and 4 (each within the scatter of the next).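

Among these compounds, this is the first measured step at the 4-fluorophenyl group, and in this assay it reads as a number 4.8 percentage points higher from compound 2 to compound 4 (within the scatter) on the shared core with the pyridin-3-yl group. Chloro in place of fluoro, on an aromatic carbon of a six-membered aromatic ring of carbon only and para to a large group, thus stays within the scatter, as do the three exchanges of the aryl group on the shared core. Nothing at hand bears on the reading of this step.

The compounds shown leave open whether another group in this place, such as a methoxy group, an amine or a carboxylic acid, would move the number beyond the scatter. They also leave open how chloro in place of fluoro reads with the pyridin-4-yl or 4-cyanophenyl group on the shared core.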